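A few compounds are considered here, and "the series" means these few. Any claim that something is new, unique, unknown or untested is made for them only; others in the source may bear on it.

Compounds 1 and 2 share one core and differ only by chloro in place of fluoro on an aromatic carbon. In a functional assay on K562 cells (Homo sapiens) for cytotoxicity, read by trypan blue exclusion, with a stated time of 96 h (a higher number here means a weaker inhibitor, a lower number a stronger inhibitor), compound 1 `COC(=O)C(Nc1cc(NS(=O)(=O)/C=C/c2c(OC)cc(OC)cc2OC)ccc1OC)c1ccc(F)cc1` gives 2500 nM, and compound 2 `COC(=O)C(Nc1cc(NS(=O)(=O)/C=C/c2c(OC)cc(OC)cc2OC)ccc1OC)c1ccc(Cl)cc1` gives 2500 nM; the step is no change at the digits printed from compound 1 to compound 2 (within the scatter). Compound 3 `COc1cc(OC)c(/C=C/S(=O)(=O)Nc2ccc(OC)c(NC(C(=O)O)c3ccc(F)cc3)c2)c(OC)c1` carries the second core, which differs from the first by hydrogen in place of methyl on an oxygen next to a carbonyl group; in this assay compound 3 gives 20 nM, a large step of a 130-fold lower number from compound 1 to compound 3 (2.10 log units; beyond the scatter).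

Compound 4 `COc1cc(OC)c(/C=C/S(=O)(=O)Nc2ccc(OC)c(NC(C(=O)O)c3ccc(Cl)cc3)c2)c(OC)c1` awaits measurement in this assay. It differs from compound 3 by chloro in place of fluoro on an aromatic carbon, the same change already seen between compounds 1 and 2, at a place described in identical words, here on the core of compound 3. For compound 4 the step is expected to be a 1.3-fold higher number from compound 3 to compound 4 (0.10 log units; within the scatter), because the earlier step of no change at the digits printed from compound 1 to compound 2 (within the scatter) stayed within the scatter. Compound 4 is therefore estimated at 25 nM, between 8 nM and 80 nM.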

Compound 4, half-maximal inhibitory concentration in the K562 assay: 15 nM
Compound 4: middle estimate off by 1.7-fold (0.22 log units), on the high side; measured number inside the range.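

In the K562 assay, compound 4 gives 15 nM, and chloro in place of fluoro on an aromatic carbon carries across the two cores, the new step being a 1.3-fold lower number from compound 3 to compound 4 (0.12 log units; within the scatter): the same change on two cores in the K562 assay, no change at the digits printed (within the scatter) from compound 1 to compound 2 and a 1.3-fold lower number (0.12 log units; within the scatter) from compound 3 to compound 4, 1.3-fold (0.12 log units) apart, within the scatter of two such steps. Hydrogen in place of methyl on an oxygen next to a carbonyl group also carries across the fluoro and chloro pairs, with a 170-fold lower number from compound 2 to compound 4 (2.22 log units; beyond the scatter), and the replacement spanning both changes gives a 170-fold lower number from compound 1 to compound 4 (2.22 log units; beyond the scatter): the same change on two cores in the K562 assay, a 130-fold lower number (2.10 log units; beyond the scatter) from compound 1 to compound 3 and a 170-fold lower number (2.22 log units; beyond the scatter) from compound 2 to compound 4, 1.3-fold (0.12 log units) apart, within the scatter of two such steps. This shows agreement for these four compounds only, not a rule for other cores or substituents, and it does not explain either step. In a physicochemical assay for solubility (a higher number here means a more soluble compound, a lower number a less soluble compound), compound 3 gives 10000 ug/mL and compound 4 gives 10000 ug/mL.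

Open, from the compounds shown here alone, is whether a methyl, methoxy or nitrile group on that aromatic carbon would also leave the number within the scatter. Also open, going by these compounds, is how a primary amide or a tetrazole in place of the carboxylic acid would compare.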